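The compounds below may be only part of what the source reports. "The series", "measured", "known", "first", "only" and "open" are said of these compounds alone.

Compound 1 `CCCCCCCCCCCCSCCc1ccc(OCc2ccc(OC)cc2)c(OCc2ccc(OC)cc2)c1` in a toxicity assay on MRC5 cells (Homo sapiens) for inhibition, read by MTT assay, with a stated time of 72 h (a higher number here means a weaker inhibitor, a lower number a stronger inhibitor), gives > 50000 nM, which is a limit of the assay.
Compound 2 `CC(=O)OCCc1ccc(O)c(O)c1` in this assay gives > 50000 nM, likewise a limit.
Compound 3 `CC(=O)OCCc1ccc(O)cc1` in this assay gives 114000 nM.

Going by the values given here, compound 3 thus holds the only real number among the three; the other two values sit at a limit, as the limit of > 50000 nM in this assay, at which 2 of the 3 values shown sit, records. Among the compounds with values here, the one step between measured compounds, a step that the limit leaves unreadable from compound 2 to compound 3, cannot be read in size for that reason. Compound 4 `CCCCCC(=O)OCCc1ccc(O)cc1` differs from compound 3 by butyl in place of hydrogen on a saturated chain carbon bound to a carbonyl carbon. No measured step matches this kind of change, so none of the shown steps bears on it directly. The step of a 1.4-fold lower number from compound 3 to compound 4 (0.15 log units; within the scatter) is therefore expected to stay within the usual scatter. Compound 4 is estimated to give about 80000 nM, with a range from 30000 nM to 200000 nM.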

Compound 4, half-maximal inhibitory concentration: 166000 nM
The estimate for compound 4 lay 2.1-fold (0.32 log units) below the measured number; the measured number falls inside the stated range.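

In this assay, butyl in place of hydrogen on a saturated chain carbon bound to a carbonyl carbon gives a 1.5-fold higher number from compound 3 to compound 4 (0.16 log units; within the scatter). This position therefore carries the lengthening from methyl to pentyl with no difference that can be told from scatter, so compound 3 and compound 4 stand level here. Going by these compounds alone, it is the first step whose size can be read.

Going by these compounds, whether an amine, a carboxylic acid or a chain longer than pentyl at this position would stand apart remains open. The step from compound 2 stays unreadable because compound 2 gives only a limit: the limit of > 50000 nM in this assay, at which 2 of the 4 values shown sit.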